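Swapping chloro for methoxy on a stable amide series

The source may hold more compounds than are shown below. What is called first, only, known or untested is meant among the compounds shown, and "the series" means these compounds.

Measured compounds:
- Compound 1 `C[C@H](NC(=O)Cn1nnc2ccccc2c1=O)c1ccc(Cl)cc1`. In an ADME assay on microsomes from liver (Homo sapiens) for metabolic stability (a higher number here means faster removal of the compound, a lower number slower removal), compound 1 gives < 9.9 mL/min/kg, which is a limit of the assay and not a number.
- Compound 2 `C[C@@H](NC(=O)Cn1nnc2ccccc2c1=O)c1ccc(Cl)cc1`. In this assay compound 2 gives < 9.9 mL/min/kg, again a limit of the assay.
- Compound 3 `Cc1ccc([C@@H](C)NC(=O)Cn2nnc3ccccc3c2=O)cc1`. In this assay compound 3 gives < 9.9 mL/min/kg, also a limit of the assay.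

Compound 1 therefore stands only at a limit, and the two other values are limits as well, because of the limit of < 9.9 mL/min/kg in this assay, at which 3 of the 3 values shown sit. The step that the two limits leave unreadable from compound 1 to compound 2 cannot be sized, because the two compounds differ only in configuration (the fact that compounds 1 and 2 differ only in the configuration as drawn). The step that the two limits leave unreadable from compound 2 to compound 3 is likewise unreadable.

The unmeasured compound 4 `COc1ccc([C@H](C)NC(=O)Cn2nnc3ccccc3c2=O)cc1` differs from compound 1 as follows: methoxy in place of chloro on an aromatic carbon. Going by the values given here, no measured step carries a readable size, so no direction can be drawn from them; all three measured values simply sit at the limit. Compound 4 is expected to follow, with a step that the limit leaves unreadable from compound 1 to compound 4 that stays within the scatter. Compound 4 is estimated at 8 mL/min/kg, with a range from 4 mL/min/kg to 16 mL/min/kg.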

Compound 4, clearance: 13 mL/min/kg
The estimate for compound 4 lay 1.6-fold (0.21 log units) below the measured number; the range from low to high includes it.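

In this assay, going by these compounds alone, compound 4 gives 13 mL/min/kg, the first value in this set that is a number and not a limit of the assay, while the steps among compound 1, compound 2 and compound 3 cannot be read. At this place, on an aromatic carbon para to a large group, putting methoxy in place of chloro gives an at least 1.3-fold higher number from compound 1 to compound 4 (0.11 log units; that floor lies within the scatter). That figure is only a floor, and the true size of the step stays unknown, because compound 1 stands at a limit and has no number to start from: the limit of < 9.9 mL/min/kg in this assay, at which 3 of the 4 values shown sit.

Going by these compounds, it remains open what an amine or a carboxylic acid on the same aromatic carbon would give in this assay. Also open, on these data alone, is whether the methoxy compound with the opposite configuration at the stereocentre would sit near compound 4.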